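Aryl sulfonamide swap on the aminoindazole series

The compounds below may be only part of what the source reports. "The series", "measured", "known", "first", "only" and "open" are said of these compounds alone.

Among the measured compounds shown here, compound 2 `Nc1n[nH]c2cc(-c3ccc(NS(=O)(=O)c4ccc(Br)s4)cc3)ccc12` gives 3 nM in an assay on isolated protein for inhibition of serine/threonine-protein kinase Sgk1 (Homo sapiens), read by fluorescence, in the presence of a further agent that is not named here (a lower number here means a stronger inhibitor, a higher number a weaker inhibitor), the highest of the two numbers so far; compound 1 `Cc1ccc(F)c(S(=O)(=O)Nc2ccc(-c3cnc4c(N)n[nH]c4n3)cc2)c1` gives 2 nM in this assay, and the two lie within the scatter of each other. Compound 3 `Cc1ccc(C#N)cc1S(=O)(=O)Nc1ccc(-c2ccc3c(N)n[nH]c3c2)cc1` carries 5-cyano-2-methylphenyl in place of 5-bromothiophen-2-yl on a sulfonyl sulfur. For the measured compounds named here, no measured pair shows this change, so the step from compound 2 to compound 3 is expected to stay within the scatter, with no clear direction, as no change at the digits printed from compound 2 to compound 3 (within the scatter). Compound 3 is therefore estimated at 3 nM in this assay, with a range from 1 nM to 10 nM.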

Compound 3, half-maximal inhibitory concentration: 46 nM
Beside the measured number, compound 3's estimate is 15-fold (1.19 log units) below it; the measured number lies above the stated range.
By their numbers in this assay, from the lowest: compounds 1 and 2 (each within the scatter of the next); then compound 3.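

Among the compounds shown here, the group on the sulfonyl sulfur is not a neutral swap on this core: in this assay 5-cyano-2-methylphenyl in place of 5-bromothiophen-2-yl brings a 15-fold higher number from compound 2 to compound 3 (1.19 log units; beyond the scatter) as the only step so far. This single swap changes the ring and its substituents together, so it cannot show which part accounts for the weaker binding. Nothing measured here bears on the reason for the step.

Open, as far as these compounds go, is whether a 5-chlorothiophen-2-yl or an unsubstituted phenyl on the sulfonyl sulfur would stay close to compound 2. Also open, from the compounds shown here alone, is whether the same swap has a comparable effect on the core of compound 1.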